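Swapping the carbamate's tert-butyl for an oxolane ring

The source may report more compounds than this note shows. Statements on the series, on what has been measured and on what is new or still open speak of the compounds shown alone.

Of the compounds shown here, three sharing one core have been tested in a functional assay on isolated protein for agonist activity at Glucose-dependent insulinotropic receptor (Homo sapiens), read by HTRF and cAMP accumulation; on this read-out lower numbers stand for smaller maximal responses and higher numbers for larger maximal responses. Compound 1 `CC(C)(C)OC(=O)N1CCC(O[C@H]2CC[C@H](Oc3ccc(C#N)cc3)CC2)CC1` gives 116%. Compound 2 `CC(C)(C)OC(=O)N1CCC(O[C@H]2CC[C@H](Oc3cnc(S(C)(=O)=O)cn3)CC2)CC1` gives 110%, and compound 3 `CC(C)(C)OC(=O)N1CCC(O[C@H]2CC[C@H](Oc3ccc(S(C)(=O)=O)nn3)CC2)CC1` gives 97%. Among these three numbers, compound 2 stands second highest: the step of a number 6 percentage points lower from compound 1 to compound 2 (within the scatter) is within the scatter, whereas a number 13 percentage points lower from compound 2 to compound 3 (beyond the scatter) lies beyond it, as does a number 19 percentage points lower from compound 1 to compound 3 (beyond the scatter). Every one of these measured steps exchanges the ring that sits on an oxygen on a saturated carbon, and none of them is large.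

Compound 4 `CS(=O)(=O)c1cnc(O[C@H]2CC[C@H](OC3CCN(C(=O)OC4CCOC4)CC3)CC2)cn1` differs from compound 2 at a different place: oxolan-3-yl in place of tert-butyl on an oxygen next to a carbonyl group. The exchanged group sits on an oxygen next to a carbonyl group, whose other neighbour is the carbonyl carbon, and the difference cut one bond further out reads tert-butoxycarbonyl to ((oxolan-3-yl)oxy)carbonyl. None of the three measured steps touches this part of the molecule, so there is no measured guide for this change; the expectation is a step of no clear direction and within the scatter. Compound 4 is therefore expected to give 108%, with a range from 92% to 124%. This estimate corresponds to an expected step of a number 2 percentage points lower from compound 2 to compound 4 (within the scatter).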

Compound 4, largest response reached (Emax), in percent of the reference or control that the assay uses: 105%
The estimate for compound 4 lay 3 percentage points above the measured number, and the stated range covers the measured number.
By their numbers in this assay, from the lowest: compounds 3, 4, 2 and 1 (each within the scatter of the next, the first and the last beyond it).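

The measured step gives this end of the molecule its first data point in this assay: oxolan-3-yl in place of tert-butyl on an oxygen next to a carbonyl group gives a number 5 percentage points lower from compound 2 to compound 4 (within the scatter) and so leaves the maximal response within the usual scatter. The earlier compounds shown here varied only the ring at the other end of the molecule, whereas this result shows that the response can survive a change here too, even though the entering group brings a five-membered non-aromatic ring and 1 hydrogen-bond acceptor that tert-butyl does not have. No available measurement accounts for this outcome, so it can be reported only as an observation.

Going by these compounds alone, this exchange is seen only with 5-(methylsulfonyl)pyrazin-2-yl at the other end of the molecule, so it remains open whether it would behave the same way with 4-cyanophenyl or 6-(methylsulfonyl)pyridazin-3-yl. Also open, on these data alone, is how the same place would respond to a group carrying an amine, such as piperidin-4-yl, or to a carboxylic acid on a longer chain.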